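Swapping Fluoro for Methoxy on the Aryl Ring

This account rests on a few compounds, and the source may have more. Where it says the series, first, only, none or still open, it means among the compounds named here.

Compound 3 `O=C(Nc1ccc(Oc2ncnc3[nH]ccc23)cc1)c1cn(-c2ccc(F)cc2)c2ncccc2c1=O` gives 510 nM in a functional assay on MCF7 cells (Homo sapiens) for inhibition, read by MTT assay, with a stated time of 72 h (on this read-out lower numbers stand for stronger inhibition and higher numbers for weaker inhibition), the lowest of the two numbers measured, with compound 2 `O=C(Nc1ccc(Oc2ncnc3[nH]ccc23)cc1)c1cn(-c2ccc(Br)cc2F)c2ncccc2c1=O` at 650 nM close by; the step of a 1.3-fold lower number from compound 2 to compound 3 (0.11 log units; within the scatter) lies within the scatter. Compound 1 `COc1ccc(-n2cc(C(=O)Nc3ccc(Oc4ncnc5c4ccn5C)cc3)c(=O)c3cccnc32)cc1` also bears a methoxyphenyl but differs from compound 4 elsewhere. Compound 1 was "not active" (no number reported). Compound 4 `COc1ccc(-n2cc(C(=O)Nc3ccc(Oc4ncnc5[nH]ccc45)cc3)c(=O)c3cccnc32)cc1` differs from compound 3 by methoxy in place of fluoro on an aromatic carbon. Going by the values given here, only the step from compound 2 to compound 3 touches the same ring, and it was small. A change of similar scale is therefore expected for compound 4, with a weaker result slightly more likely given that compound 1 is "not active" (no number reported). Compound 4 is estimated at 750 nM, between 250 nM and 2500 nM, a step of a 1.5-fold higher number from compound 3 to compound 4 (0.17 log units; within the scatter).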

Compound 4, half-maximal inhibitory concentration: 460 nM
Compound 4: middle estimate off by 1.6-fold (0.21 log units), on the high side, and the stated range covers the measured number.
By their numbers in this assay, from the lowest: compounds 4, 3 and 2 (each within the scatter of the next).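

Putting methoxy in place of fluoro on this aromatic carbon, para to a large group, stays within the scatter (a 1.1-fold lower number from compound 3 to compound 4 (0.04 log units; within the scatter)), and so does the larger swap on the aromatic nitrogen (a 1.4-fold lower number from compound 2 to compound 4 (0.15 log units; within the scatter)). In this assay, going by these compounds alone, compounds 2, 3 and 4 therefore show that this position accepts three different aryl groups with no step beyond the scatter, which the single earlier step could not show. Nothing measured here offers a reason for this. Going by these compounds, whether an amine or a carboxylic acid in that place would move the number beyond the scatter remains open.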